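Swapping Pyrimidine for Thiadiazole on the Amino Linker

The source may report more compounds than this note shows. Statements on the series, on what has been measured and on what is new or still open speak of the compounds shown alone.

Measured so far:
compound 1, `CC(Oc1cccnc1Nc1cnn(C)c1)c1cccc(C(=O)NCc2ccc(F)c(Cl)c2)c1`: 7800 nM
compound 2, `Cc1ccc(CNC(=O)c2cccc(C(C)Oc3cccnc3Nc3ncccn3)c2)cc1`: > 100000 nM

In a functional assay on HCC78 cells (Homo sapiens) for antiproliferative activity, read by MTT assay, with a stated time of 48 h (on this read-out lower numbers stand for stronger inhibition and higher numbers for weaker inhibition), compound 1 gives 7800 nM. For compound 2 the record holds only a limit, > 100000 nM, which marks the edge of the assay rather than a measured number; this is the limit of > 100000 nM in this assay, at which 1 of the 2 values shown sits. Compound 3, `Cc1ccc(CNC(=O)c2cccc(C(C)Oc3cccnc3Nc3nncs3)c2)cc1`, has not yet been measured in this assay. It differs from compound 2 in one place: 1,3,4-thiadiazol-2-yl in place of pyrimidin-2-yl on a nitrogen on an aromatic ring. Among the measured compounds shown here, no step between two measured compounds is recorded, so the size of this change cannot be read from the data at hand. Compound 3 is therefore expected to land near where compound 2 sits, and the step of an at least 1.2-fold lower number from compound 2 to compound 3 (0.09 log units; that floor lies within the scatter) is the one its estimate implies. For compound 3 the estimated value in this assay is 80000 nM, within a range from 20000 nM to 300000 nM, and a fair chance remains that only a limit is reported again.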

Compound 3, half-maximal inhibitory concentration: 17600 nM
The estimate for compound 3 lay 4.5-fold (0.66 log units) above the measured number; the whole stated range lies above it.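

Compound 2 holds only a limit, not a measured number: the limit of > 100000 nM in this assay, at which 1 of the 3 values shown sits. On a nitrogen on an aromatic ring, the position proves sensitive to the group it carries: in this assay, 1,3,4-thiadiazol-2-yl in place of pyrimidin-2-yl gives an at least 5.6-fold lower number from compound 2 to compound 3 (0.75 log units; beyond the scatter), bringing the series from that limit to a measured number. As one end of this step is a limit, its true size may be larger than printed.

The change swaps a six-membered aromatic ring for a five-membered one and brings in sulfur, and the compounds shown do not tell these two differences apart. From the compounds shown here alone, a 1,3,4-oxadiazol-2-yl group, with oxygen in the place of the sulfur, would speak to that question, and how far the step carries over to other amides of the core also remains open.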